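The compounds below may be only part of what the source reports. "The series", "measured", "known", "first", "only" and "open" are said of these compounds alone.

The measured compounds:
Compound 1 `CC1=CC[C@@H]([C@@](C)(O)CCCC(C)(C)NC(=S)N/N=C\c2ccccc2)CC1` gives in a functional assay on K562 cells (Homo sapiens) for cytotoxicity, read by sulforhodamine B assay (a higher number here means that more compound is tolerated, a lower number that less compound is tolerated), a value of > 100000 nM, which is a limit of the assay and not a number.
Compound 2 `CC1=CC[C@@H]([C@@](C)(O)CCCC(C)(C)NC(=S)N/N=C\c2ccc(C)cc2)CC1` gives in this assay a value of > 100000 nM, again a limit of the assay.

Compound 2 therefore stands at the limit of > 100000 nM in this assay, at which 2 of the 2 values shown sit, with no number of its own. Within the data shown here, the single measured step, a step that the two limits leave unreadable from compound 1 to compound 2, is unreadable, so the effect of methyl in place of hydrogen on an aromatic carbon on this assay is not known.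

Compound 3 `CC1=CC[C@@H]([C@@](C)(O)CCCC(C)(C)NC(=S)N/N=C\c2cccc(Cl)c2)CC1` differs from compound 2 by 3-chlorophenyl in place of 4-methylphenyl on a carbon with a double bond to nitrogen. Among the measured compounds shown here, no measured step bears on this change, and the one step known gives no size. Compound 3 is therefore expected to stay at the same limit, so that the step that the limit leaves unreadable from compound 2 to compound 3 is expected to be none beyond the scatter. For compound 3 the estimate in this assay is 150000 nM, within a range from 50000 nM to 500000 nM.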

Compound 3, concentration lethal to 50% of the cells: 56300 nM
The estimate for compound 3 lay 2.7-fold (0.43 log units) above the measured number; the measured number falls inside the stated range.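

In this assay compound 3 is the first compound shown to give a number and not a limit, so a change on the carbon with a double bond to nitrogen can now be sized, if only from one side. The change to 3-chlorophenyl gives an at least 1.7-fold lower number from compound 2 to compound 3 (0.24 log units; that floor lies within the scatter), and the added chloro group gives an at least 1.7-fold lower number from compound 1 to compound 3 (0.24 log units; that floor lies within the scatter). Neither floor goes beyond the scatter, so no real shift is established, and the step between the other two compounds still cannot be read, as the values of compound 1 and compound 2 are limits: the limit of > 100000 nM in this assay, at which 2 of the 3 values shown sit.

The compounds shown leave open how far the true steps reach. They also leave open whether 4-chlorophenyl or an aminophenyl group at the same place would give a number in this assay.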